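The source may report more compounds than this note shows. Statements on the series, on what has been measured and on what is new or still open speak of the compounds shown alone.

This study follows a small set of compounds that share one core and asks how readily each dissolves. Compound 1 `COC(=O)c1nc(C)c2c(c1N)C(=O)N(Cc1ccccc1)C2=O` was tested in a physicochemical assay for solubility, using the shake flask method, in simulated intestinal fluid, measured as kinetic solubility, with a stated time of 2 h, at 25 degrees C, at pH 6.5 (on this read-out lower numbers stand for lower solubility and higher numbers for higher solubility), where compound 1 gives 7400 nM. Compound 2 `CNC(=O)c1nc(C)c2c(c1N)C(=O)N(Cc1ccccc1)C2=O` carries a methylamino in place of methoxy on a carbonyl carbon, and in this assay compound 2 gives 41000 nM. That single change produced a 5.5-fold higher number from compound 1 to compound 2 (0.74 log units; beyond the scatter). Compound 3 `Cc1noc(-c2nc(C)c3c(c2N)C(=O)N(Cc2ccc(-n4cccn4)cc2)C3=O)n1` is built differently at two positions of the core. In this assay compound 3 gives < 5000 nM, which is a limit of the measurement rather than a number. This is the limit of < 5000 nM in this assay, at which 1 of the 3 values shown sits, so compound 3 stands at the low end of what has been seen, and no finer placement is possible.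

Compound 4 `Cc1noc(-c2nc(C)c3c(c2N)C(=O)N(Cc2ccc(OC(F)F)cc2)C3=O)n1` differs from compound 3 in one place: difluoromethoxy in place of 1H-pyrazol-1-yl on an aromatic carbon. For the measured compounds named here, the only measured step concerns a group on a carbonyl carbon, a different part of the molecule, and no measured step touches the group on the six-membered ring. Going by the values given here, the change from compound 3 to compound 4 therefore has no precedent here, and no movement beyond the scatter is expected, with the change estimated as a step that the limit leaves unreadable from compound 3 to compound 4. Compound 4 is expected to give about 4000 nM in this assay, within a likely range from 1500 nM to 11000 nM.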

Compound 4, solubility: < 5000 nM
Compound 4: no number, only a limit; the forecaster's own chance of this, stated with the estimate: 55%; the middle value lies beyond the limit too.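

Compound 3 and compound 4 each give only a limit in this assay, not a number, so the step of difluoromethoxy in place of 1H-pyrazol-1-yl cannot be read: the limit of < 5000 nM in this assay, at which 2 of the 4 values shown sit.

The compounds shown leave open what number either compound would give, and whether this change on the aromatic carbon moves the read-out at all.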